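The source may hold more compounds than are shown below. What is called first, only, known or untested is meant among the compounds shown, and "the series" means these compounds.

Going by the values given here, compound 2 `O=C(Nc1c(C(O)(C(F)(F)F)C(F)(F)F)ccc2ccccc12)C1CCC1` gives in an assay on LtK cells with ATP-sensitive inward rectifier potassium channel 11 (Homo sapiens) as the target (a lower number here means that less compound is needed, a higher number that more compound is needed for the effect), 45 nM, the lowest of the two numbers known so far; compound 1 `CC(C)C(=O)Nc1c(C(O)(C(F)(F)F)C(F)(F)F)ccc2ccccc12` gives 6630 nM. Among the compounds with values here, the single measured step, a 150-fold lower number from compound 1 to compound 2 (2.17 log units; beyond the scatter), shows that the group on the carbonyl carbon moves the number strongly. Compound 3 `Cc1ccccc1C(=O)Nc1c(C(O)(C(F)(F)F)C(F)(F)F)ccc2ccccc12` differs from compound 2 as follows: 2-methylphenyl in place of cyclobutyl on a carbonyl carbon. That measured step bears on this change only by showing how sensitive this position is, and no aromatic group has been measured at it, so the direction is open. Compound 3 is expected to give about 150 nM, within a range of 20 nM to 1500 nM. The expected step is a 3.3-fold higher number from compound 2 to compound 3 (0.52 log units; beyond the scatter), judged modest.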

Compound 3, half-maximal effective concentration: 5550 nM
Compound 3: middle estimate off by 37-fold (1.57 log units), on the low side; the whole stated range lies below it.
By their numbers in this assay, from the lowest: compound 2; then compounds 3 and 1 (each within the scatter of the next).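

In this assay the move from cyclobutyl to 2-methylphenyl on the carbonyl carbon gives a 120-fold higher number from compound 2 to compound 3 (2.09 log units; beyond the scatter) and so takes the number back out of the low range. The step from isopropyl to 2-methylphenyl, a 1.2-fold lower number from compound 1 to compound 3 (0.08 log units; within the scatter) in size, shows that among these three groups only cyclobutyl stands apart, and that a ring alone at this position does not give the low number. Nothing available explains this result. Open, from the compounds shown here alone, is whether cyclopropyl or cyclopentyl would share the low number of cyclobutyl. Also open, going by these compounds, is whether plain phenyl would behave like 2-methylphenyl.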